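Amide substituent series: hexyl to cyclopentyl step

The compounds below may be only part of what the source reports. "The series", "measured", "known", "first", "only" and "open" are said of these compounds alone.

Measured so far:
compound 1 `CCCNC(=O)CC1CCc2cc(OC)c(OC)cc21` — 18.8%
compound 2 `COc1cc2c(cc1OC)C(CC(=O)NC(C)(C)C)CC2` — 31.3%
compound 3 `CCCCCCNC(=O)CC1CCc2cc(OC)c(OC)cc21` — 47.6%

All three share a core and differ only in the group on the amide-type nitrogen. In a functional assay on the whole organism (strain Wistar) for inhibition, with Rattus norvegicus as the target, read by paw edema, with stated times of 60 min and 1 h, at a dose of 100 mg/kg by the oral route (on this read-out lower numbers stand for less inhibition and higher numbers for more inhibition at the one dose given (going by the name of the read-out)), compound 3 stands highest of the three: the nearest number is that of compound 2, reached by a number 16.3 percentage points higher from compound 2 to compound 3 (beyond the scatter), and the furthest is that of compound 1, reached by a number 28.8 percentage points higher from compound 1 to compound 3 (beyond the scatter). Across this set the number rises as the group on the amide-type nitrogen grows from propyl through tert-butyl to hexyl.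

Compound 4 `COc1cc2c(cc1OC)C(CC(=O)NC1CCCC1)CC2` is not yet measured. Its change from compound 3 is cyclopentyl in place of hexyl on an amide-type nitrogen. Among the compounds with values here, the steps that bear on it are those along the same nitrogen: a number 12.5 percentage points higher from compound 1 to compound 2 (beyond the scatter) and a number 16.3 percentage points higher from compound 2 to compound 3 (beyond the scatter), both modest and both beyond the scatter. Cyclopentyl is smaller than hexyl by one carbon and carries a ring instead of a chain; no measured compound carries a ring there, so the direction rests on the trend in size alone. The expectation is therefore a modest fall in this assay, about a number 10.6 percentage points lower from compound 3 to compound 4 (beyond the scatter), placing compound 4 near compound 2 rather than compound 3. Compound 4 is estimated at 37%, with a range of 24% to 50%.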

Compound 4, a percentage reported as inhibition, in the whole organism at one dose (the size of the read-out at that dose, not a potency): 40.6%
Compound 4: the middle estimate sits 3.6 percentage points below what was measured; measured number inside the range.
By their numbers in this assay, from the lowest: compound 1; then compounds 2, 4 and 3 (each within the scatter of the next, the first and the last beyond it).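

In this assay, the first ring on the amide-type nitrogen gives no clear separation from the open chain: with a number 7 percentage points lower from compound 3 to compound 4 (within the scatter) the exchange of hexyl, 6 heavy atoms and no ring, for cyclopentyl, 5 heavy atoms in one five-membered ring, stays inside the usual scatter. Cyclopentyl is equally unresolved from the branched group, with a number 9.3 percentage points higher from compound 2 to compound 4 (within the scatter) also inside the scatter, even though tert-butyl and hexyl are resolved from each other, so compound 4 cannot be assigned to either side of that gap. Propyl alone stands clearly apart from cyclopentyl, with a number 21.8 percentage points higher from compound 1 to compound 4 (beyond the scatter) beyond the scatter, and nothing available accounts for any of these steps.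

As far as these compounds go, it remains open whether a ring at this nitrogen differs from an open chain of matching size, a question that cyclohexyl or cyclobutyl on the same amide would address. Also open, from the compounds shown here alone, is whether the rise from propyl continues or levels off with a longer chain such as octyl, and how an aromatic group such as phenyl or benzyl would read at this one dose.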